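A few compounds are considered here, and "the series" means these few. Any claim that something is new, unique, unknown or untested is made for them only; others in the source may bear on it.

Measured compounds:
compound 1 `CC(=O)OCCc1c(-c2ccccc2Cl)c2cc(Cl)ccc2[nH]c1=O` with 27000 nM
compound 2 `CCCC(=O)OCCc1c(-c2ccccc2Cl)c2cc(Cl)ccc2[nH]c1=O` with 52000 nM
compound 3 `CCCCC(=O)OCCc1c(-c2ccccc2Cl)c2cc(Cl)ccc2[nH]c1=O` with 200000 nM

All three share a core that differs only in the ester group on the side chain, and all were tested in an ADME assay on HepG2 2.2.15 cells (Homo sapiens) for cytotoxicity; on this read-out higher numbers stand for lower toxicity in this test and lower numbers for higher toxicity in this test. Among them compound 1 gives the lowest number; compound 2 sits a 1.9-fold higher number from compound 1 to compound 2 (0.28 log units; within the scatter), and compound 3 sits a 7.4-fold higher number from compound 1 to compound 3 (0.87 log units; beyond the scatter), with a 3.8-fold higher number from compound 2 to compound 3 (0.59 log units; beyond the scatter) separating the latter two.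

Compound 4 `O=C(OCCc1c(-c2ccccc2Cl)c2cc(Cl)ccc2[nH]c1=O)C1CCCCC1` has not yet been tested. It differs from compound 1 in one place: cyclohexyl in place of methyl on a carbonyl carbon. Within the data shown here, the steps that bear on this are the lengthenings from compound 1 to compound 2 and to compound 3, in which each added carbon on the acyl group raised the number in this assay, the larger of the two steps modestly beyond the scatter. Cyclohexyl is a larger group than propyl, so an increase beyond the scatter is expected for compound 4, though the data give no step for a ring in this position. Compound 4 is therefore estimated at 150000 nM, in the range 50000 nM to 400000 nM, a step of a 5.6-fold higher number from compound 1 to compound 4 (0.74 log units; beyond the scatter) expected from compound 1.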

Compound 4, half-maximal cytotoxic concentration: 38000 nM
Beside the measured number, compound 4's estimate is 3.9-fold (0.60 log units) above it; the whole stated range lies above it.
By their numbers in this assay, from the lowest: compounds 1, 4 and 2 (each within the scatter of the next); then compound 3.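

In this assay, a ring on this carbonyl carbon does not continue the rise seen along the straight chains: cyclohexyl in place of methyl gives a 1.4-fold higher number from compound 1 to compound 4 (0.15 log units; within the scatter) and cyclohexyl in place of propyl gives a 1.4-fold lower number from compound 2 to compound 4 (0.14 log units; within the scatter), so neither step separates the ring from the shorter esters. Cyclohexyl in place of butyl gives a 5.3-fold lower number from compound 3 to compound 4 (0.72 log units; beyond the scatter), which shows that at this position the number does not follow the count of added carbons alone, with compound 4 going against the trend set by the chains. No measurement is available that would account for this difference between the ring and the open chain.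

As far as these compounds go, it remains open whether a longer chain such as hexyl would carry the rise further. From the compounds shown here alone, it is equally open whether a smaller ring such as cyclopropyl, a branched group such as tert-butyl, or an aromatic phenyl ring would behave like cyclohexyl or like butyl.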